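The source may report more compounds than this note shows. Statements on the series, on what has been measured and on what is new or still open speak of the compounds shown alone.

Measured compounds:
Compound 1, `O=C(NCCCCc1ccccc1)n1cnc2ccccc21`, gives 2.5 nM in an assay on HEK293 cells for inhibition of acid ceramidase (Homo sapiens), read by fluorescence, with stated times of 30 min and 1 h; a lower number here means a stronger inhibitor, a higher number a weaker inhibitor.
Compound 2, `CCCCCCNC(=O)n1cnc2ccccc21`, gives 6.6 nM in this assay.

Within the data shown here, compound 2 has the higher of the two numbers and is thus the weaker inhibitor of the pair; the only measured step, a 2.6-fold higher number from compound 1 to compound 2 (0.42 log units; beyond the scatter), separates the two. The unmeasured compound 3, `CCCCCCNC(=O)n1c(N)nc2ccccc21`, keeps the whole of compound 2 and differs in a single spot: amino in place of hydrogen on an aromatic carbon. The amino group sits on the shared core, between two ring nitrogen atoms, far away from the hexyl chain. Among the measured compounds shown here, no measured step touches this part of the molecule: the one step seen so far, from compound 1 to compound 2, concerns the end of the chain, four bonds along from the amide-type nitrogen, and tells nothing about what a change on the core does. With no guide in the data, the expectation for this assay is a step of a 1.2-fold higher number from compound 2 to compound 3 (0.08 log units; within the scatter), not beyond the usual scatter, in either direction. Compound 3 is therefore estimated at 8 nM, with a range from 2 nM to 40 nM.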

Compound 3, half-maximal inhibitory concentration: 2.4 nM
Compound 3: the middle estimate sits 3.3-fold (0.52 log units) above what was measured; measured number inside the range.
By their numbers in this assay, from the lowest: compounds 3 and 1 (each within the scatter of the next); then compound 2.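

Placing amino in place of hydrogen on this aromatic carbon, between two ring nitrogen atoms, gives in this assay a 2.8-fold lower number from compound 2 to compound 3 (0.44 log units; beyond the scatter), so compound 3 is the stronger inhibitor of this pair. The step is modest, but it shows that this position on the shared core is not silent: a change here, and not only a change in the chain, can move the number. Here, a group of just 1 heavy atom is enough to produce a step of about the same size as the one seen earlier between a phenyl-ended chain and a hexyl chain, and no measurement shown bears on the cause of this step.

Going by these compounds, whether other groups on this same carbon, such as methyl, hydroxyl, methylamino or dimethylamino, would lower the number further or raise it remains open. Equally open, on these data alone, is whether amino on the core of compound 1, with its chain ending in phenyl, would bring a step of similar size or whether the effect seen here holds only with the hexyl chain.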